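Same Methyl Step Tried on a Second Core

The source may hold more compounds than are shown below. What is called first, only, known or untested is meant among the compounds shown, and "the series" means these compounds.

Compound 1, with the structure `COc1cc(OC)cc(C(=O)NNC(=S)Nc2csc(-c3ccccc3)c2)c1`, was tested in a functional assay on U-373MG ATCC cells (Homo sapiens) for inhibition, read by colorimetric assay and MTT assay, with a stated time of 72 h (a higher number here means a weaker inhibitor, a lower number a stronger inhibitor), where compound 1 gives 40000 nM. Compound 2, `COc1cc(OC)cc(C(=O)NNC(=S)Nc2csc(-c3ccc(C)cc3)c2)c1`, carries methyl in place of hydrogen on an aromatic carbon relative to compound 1; in this assay compound 2 gives 41000 nM. The step is a 1.0-fold higher number from compound 1 to compound 2 (0.01 log units; within the scatter). Compound 3, `COc1ccc(C(=O)NNC(=S)Nc2csc(-c3ccccc3)c2)cc1OC`, is built on a different core; the difference between the two cores is not broken down here. In this assay compound 3 gives 59000 nM, and its value sits close to those of compound 1 and compound 2, so no order among the three can be read. Compound 4, `COc1ccc(C(=O)NNC(=S)Nc2csc(-c3ccc(C)cc3)c2)cc1OC`, has not yet been measured. It differs from compound 3 by methyl in place of hydrogen on an aromatic carbon, the same change already seen between compound 1 and compound 2, at the same place on the ring. Because that earlier change produced a 1.0-fold higher number from compound 1 to compound 2 (0.01 log units; within the scatter), a similarly flat step is expected here, namely a 1.0-fold higher number from compound 3 to compound 4 (0.01 log units; within the scatter). On that basis compound 4 is estimated to give 60000 nM in this assay, with a likely range from 30000 nM to 120000 nM.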

Compound 4, half-maximal inhibitory concentration: 47000 nM
Beside the measured number, compound 4's estimate is 1.3-fold (0.11 log units) above it, and the stated range covers the measured number.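

In this assay, the step on the second core is a 1.3-fold lower number from compound 3 to compound 4 (0.10 log units; within the scatter), so phenyl to 4-methylphenyl again stays inside the usual spread of repeated measurements. Set side by side, the two steps agree: the same change on two cores in this assay, a 1.0-fold higher number (0.01 log units; within the scatter) from compound 1 to compound 2 and a 1.3-fold lower number (0.10 log units; within the scatter) from compound 3 to compound 4, 1.3-fold (0.11 log units) apart, within the scatter of two such steps. This shows that, in these two pairs, the methyl change carries over from one core to the other as a flat step, but two pairs in one cell assay do not show that it would stay flat on other cores, and they cannot separate a small real difference between the two cores from scatter.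

The compounds shown leave open whether a different group in the same place on the ring, such as an amine, a carboxylic acid or a longer chain like butyl, would give a step beyond the scatter. They also leave open whether any such group would behave alike on both cores, as methyl does here.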